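From Methoxycarbonyl to Carboxy at the Assay Ceiling

The source may hold more compounds than are shown below. What is called first, only, known or untested is meant among the compounds shown, and "the series" means these compounds.

Compound 3 `COC(=O)/C=C(\C)C[C@@H](OC(C)=O)[C@@]1(C)[C@H](C)CC=C2[C@@H]1CCCC2(C)C` stands at a limit rather than at a number. In a functional assay on HL-60 cells (Homo sapiens) for cytotoxicity, read by MTT assay, with a stated time of 72 h (on this read-out lower numbers stand for stronger inhibition and higher numbers for weaker inhibition), compound 3 gives > 30000 nM, which is a limit of the assay. Compound 1 `CC(=O)O[C@H](C/C(C)=C/CO)[C@@]1(C)[C@H](C)CC=C2[C@@H]1CCCC2(C)C` gives > 30000 nM in this assay, again a limit. Compound 2 `CCC(=O)OC/C=C(\C)C[C@@H](O)[C@@]1(C)[C@H](C)CC=C2[C@@H]1CCCC2(C)C` gives > 30000 nM in this assay, once more a limit. All three shown values thus sit at the same ceiling (the limit of > 30000 nM in this assay, at which 3 of the 3 values shown sit), and compound 3 stands among them without a number of its own.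

The change under review is hydrogen in place of methyl on an oxygen next to a carbonyl group. Compound 4 `CC(=O)O[C@H](C/C(C)=C/C(=O)O)[C@@]1(C)[C@H](C)CC=C2[C@@H]1CCCC2(C)C` is the result. Among the measured compounds shown here, one measured step touches the same chain end, a step that the two limits leave unreadable from compound 1 to compound 3, methoxycarbonyl in place of hydroxymethyl on a double-bonded chain carbon bound to a double-bonded chain carbon, and its size cannot be read because both ends sit at the limit (the limit of > 30000 nM in this assay, at which 3 of the 3 values shown sit). Nothing measured here gives a direction for the step to compound 4, so no step beyond the scatter is expected in this assay. The step is estimated as a step that the limit leaves unreadable from compound 3 to compound 4. Compound 4 is expected to give 50000 nM, within 15000 nM to 200000 nM, most probably reported again only as a limit.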

Compound 4, half-maximal inhibitory concentration: > 30000 nM
Compound 4: a limit, no number; the forecaster's own chance of this, stated with the estimate: 85%; the middle value is on the limit's open side.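

Compound 4 also stands at a limit, so neither its step from compound 3 nor its step from compound 1 can be read in this assay: the limit of > 30000 nM in this assay, at which 4 of the 4 values shown sit.

The compounds shown leave open how hydroxymethyl, methoxycarbonyl and carboxy at this chain end rank against one another, and which change to the shared core would yield a readable number.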